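The source may hold more compounds than are shown below. What is called first, only, known or untested is meant among the compounds shown, and "the series" means these compounds.

Measured in a functional assay on MGC-803 cells (Homo sapiens) for inhibition, read by MTT assay, with a stated time of 48 h; on this read-out higher numbers stand for weaker inhibition and lower numbers for stronger inhibition:
- compound 1 `C/C=C/C=C/C(=O)N(Cc1ccc(OC)c(O)c1)c1cc(OC)c(OC)c(OC)c1`: 140 nM
- compound 2 `CC/C=C/C(=O)N(Cc1ccc(OC)c(O)c1)c1cc(OC)c(OC)c(OC)c1`: 58 nM
- compound 3 `COc1ccc(CN(C(=O)CCl)c2cc(OC)c(OC)c(OC)c2)cc1O`: 84 nM

Compound 3, at 84 nM, cannot be separated from either of the other two compounds. The data show a 1.7-fold lower number from compound 1 to compound 3 (0.22 log units; within the scatter) and a 1.4-fold higher number from compound 2 to compound 3 (0.16 log units; within the scatter).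

The next compound is compound 4 `COc1ccc(CN(C(=O)C2CC2)c2cc(OC)c(OC)c(OC)c2)cc1O`. The change is cyclopropyl in place of chloromethyl on a carbonyl carbon, in words cyclopropyl in place of chloromethyl on a carbonyl carbon.

The three measured compounds differ only in the group on this carbonyl carbon, so their steps are the nearest guide. The largest is modest: a 2.4-fold lower number from compound 1 to compound 2 (0.38 log units; beyond the scatter). The two steps that remove or introduce chloromethyl stay within the scatter. Among the compounds with values here, no measured compound carries cyclopropyl, so the direction of the step is not defined by the data. On the evidence of compound 3 at 84 nM and compound 2 at 58 nM, a change in this assay beyond the scatter is not expected, and the range is kept wide to allow for the new ring.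

The expected step is a 1.2-fold higher number from compound 3 to compound 4 (0.08 log units; within the scatter).

Compound 4 is estimated at 100 nM, with an expected range of 35 nM to 300 nM.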

Compound 4, half-maximal inhibitory concentration: 59 nM
Compound 4: the middle estimate sits 1.7-fold (0.23 log units) above what was measured, and the stated range covers the measured number.
By their numbers in this assay, from the lowest: compounds 2, 4, 3 and 1 (each within the scatter of the next, the first and the last beyond it).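

In this assay, cyclopropyl and chloromethyl on a carbonyl carbon whose other neighbour is the amide-type nitrogen cannot be separated (a 1.4-fold lower number from compound 3 to compound 4 (0.15 log units; within the scatter)), so at this position a ring of carbon only reads the same as a chain bearing chlorine. Cyclopropyl also cannot be separated from but-1-en-1-yl (a 1.0-fold higher number from compound 2 to compound 4 (0.01 log units; within the scatter)), which gives this place three groups of different shape with numbers that stay together, while the step from penta-1,3-dien-1-yl is modest (a 2.4-fold lower number from compound 1 to compound 4 (0.38 log units; beyond the scatter)) and is the second step beyond the scatter from compound 1, though compound 3 goes against any clean split because it stays within the scatter of compound 1. No measurement bears on why these groups read as they do.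

The compounds shown leave open how an amine or a carboxylic acid on this carbonyl carbon would read in this assay. They also leave open whether a larger carbon ring such as cyclohexyl, or a longer saturated chain, would stay with compound 4 or move towards compound 1.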